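Compound 2 to compound 4: fluoro out, hydrogen in

The source may hold more compounds than are shown below. What is called first, only, known or untested is meant among the compounds shown, and "the series" means these compounds.

Measured so far in a functional assay on NCI-N87 cells (Homo sapiens) for inhibition, read by CellTiter-Glo, with a stated time of 72 h (on this read-out lower numbers stand for stronger inhibition and higher numbers for weaker inhibition), for this series:
- compound 1 `Cc1cc(Nc2ncnc3cc(O)c(NC(=O)/C=C/[C@H]4CCCN4C)cc23)ccc1Oc1cnc2ccnn2c1` gives 1.9 nM
- compound 2 `C=C(F)C(=O)Nc1cc2c(Nc3ccc(Oc4cc5nncn5cn4)c(C)c3)ncnc2cc1OCC` gives 6.56 nM
- compound 3 `Cc1cc(Nc2ncnc3cc(O)c(NC(=O)/C=C/[C@H]4CCCN4C)cc23)ccc1Oc1ccn2ncnc2c1` gives 2.65 nM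

Compound 2 stands at 6.56 nM and carries the highest number of the three, with compound 1 at 1.9 nM and compound 3 at 2.65 nM on the same read-out.

Compound 4 `C=CC(=O)Nc1cc2c(Nc3ccc(Oc4cc5nncn5cn4)c(C)c3)ncnc2cc1OCC` has not yet been measured. The change from compound 2 is hydrogen in place of fluoro on a double-bonded chain carbon bound to a carbonyl carbon and amounts to hydrogen in place of fluoro on a double-bonded chain carbon bound to a carbonyl carbon, so that (1-fluoroethenyl)carbonyl becomes vinylcarbonyl.

For the measured compounds named here, the only measured step is a 1.4-fold higher number from compound 1 to compound 3 (0.14 log units; within the scatter) and it concerns a different change, on an oxygen on an aromatic ring. Going by the values given here, it gives no direct reading on this replacement, and no measured pair tests fluoro against hydrogen at this place. No step beyond the scatter is therefore expected in this assay, and the range is kept wide. The expected change is a 1.3-fold lower number from compound 2 to compound 4 (0.12 log units; within the scatter) and nothing larger is anticipated. Compound 4 is estimated at 5 nM with 2 nM to 14 nM as the expected range.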

Compound 4, half-maximal inhibitory concentration: 51.9 nM
Compound 4: the middle estimate sits 10-fold (1.02 log units) below what was measured, outside the stated range (above it).
By their numbers in this assay, from the lowest: compounds 1 and 3 (each within the scatter of the next); then compound 2; then compound 4.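

In this assay, hydrogen in place of fluoro on a double-bonded chain carbon bound to a carbonyl carbon gives a 7.9-fold higher number from compound 2 to compound 4 (0.90 log units; beyond the scatter). For the compounds shown here, this is the first single-place change to fall beyond the scatter, whereas the only earlier step, a 1.4-fold higher number from compound 1 to compound 3 (0.14 log units; within the scatter), lies within it and concerns a different place, on an oxygen on an aromatic ring; the read-out therefore responds to the exchange of one atom at this carbon, with (1-fluoroethenyl)carbonyl giving the lower number and vinylcarbonyl the higher one in this matched pair. Nothing available here accounts for the size or direction of this step.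

The pair cannot show whether the fluoro-to-hydrogen step is general, or whether it would carry over to other compounds in the series, since compound 1 and compound 3 bear a different amide chain. A chloro or a methyl on the same double-bonded chain carbon would show whether the read-out tracks fluoro specifically or responds to any group other than hydrogen at this place.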